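The source may report more compounds than this note shows. Statements on the series, on what has been measured and on what is new or still open speak of the compounds shown alone.

Of the compounds shown here, three built on one shared core have been measured in an assay on microsomes from liver for inhibition of 3-hydroxy-3-methylglutaryl-coenzyme A reductase (Rattus norvegicus); on this read-out lower numbers stand for stronger inhibition and higher numbers for weaker inhibition. Compound 1 `O=C(O)C[C@H](O)C[C@H](O)CCn1c(C(F)(F)F)nc(-c2ccccc2)c1-c1ccc(F)cc1` gives 31 nM. Compound 2 `O=C(O)C[C@H](O)C[C@H](O)CCn1c(C(F)(F)F)nc(-c2ccc(F)cc2)c1-c1ccc(F)cc1` gives 38 nM. Compound 3 `O=C(O)C[C@H](O)C[C@H](O)CCn1c(C(F)(F)F)nc(-c2cccs2)c1-c1ccc(F)cc1` gives 64 nM. Among these numbers compound 2 stands second highest, nearest to compound 1 and furthest from compound 3: the step of a 1.2-fold higher number from compound 1 to compound 2 (0.09 log units; within the scatter) lies within the scatter, as does a 1.7-fold higher number from compound 2 to compound 3 (0.23 log units; within the scatter), while a 2.1-fold higher number from compound 1 to compound 3 (0.31 log units; beyond the scatter) is modest and just beyond it.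

Compound 4 `Cc1ccc(-c2c(-c3ccc(F)cc3)nc(C(F)(F)F)n2CC[C@@H](O)C[C@@H](O)CC(=O)O)cc1` differs from compound 2 in one place: methyl in place of fluoro on an aromatic carbon. Going by the values given here, two measured steps bear on this. The exchange of hydrogen for fluoro on that same aromatic carbon hardly moved the number, and replacing the whole 4-fluorophenyl by thiophen-2-yl also stayed within the scatter, so small changes to that ring have so far shifted little in this assay. The step to compound 4 is therefore expected to be small, with no clear direction beyond the scatter. Compound 4 is expected to give about 40 nM, within a range from 20 nM to 80 nM. The estimated step is a 1.1-fold higher number from compound 2 to compound 4 (0.02 log units; within the scatter).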

Compound 4, half-maximal inhibitory concentration: 750 nM
The estimate for compound 4 lay 19-fold (1.27 log units) below the measured number; the measured number lies above the stated range.
By their numbers in this assay, from the lowest: compounds 1, 2 and 3 (each within the scatter of the next, the first and the last beyond it); then compound 4.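

On the six-membered aromatic ring, at the carbon para to a large group, methyl in place of fluoro gives a 20-fold higher number from compound 2 to compound 4 (1.30 log units; beyond the scatter) in this assay, even though each group counts only one heavy atom. Hydrogen and fluoro at this carbon had stayed within the scatter of each other, so the earlier compounds made the position look undemanding, whereas this single exchange shows that a small group can still weaken inhibition sharply. Nothing available here accounts for the jump.

On these data alone, it remains open whether the loss is peculiar to methyl or also appears with other groups on this carbon, such as chlorine, methoxy, ethyl or an amine. One pair also cannot tell whether the same exchange would matter as much on a different core.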